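Hydrogen in Place of Chloro on a Diaryl Urea

A few compounds are considered here, and "the series" means these few. Any claim that something is new, unique, unknown or untested is made for them only; others in the source may bear on it.

Of the compounds shown here, two have been measured in a functional assay on COLO 205 cells (Homo sapiens) for inhibition, read by sulforhodamine B assay, with a stated time of 48 h, tested at 0.1 uM; a higher number here means a weaker effect of the compound at the concentration tested, a lower number a stronger effect. Compound 1 `O=C(Nc1cccc(-n2cc(-c3ccncc3)c(-c3cc(O)cc(Cl)c3)n2)c1)Nc1ccc(Cl)c(Cl)c1` gives 103% in this assay. Compound 2 `COc1cc(Cl)cc(-c2nn(-c3cccc(NC(=O)Nc4ccc(Cl)c(C(F)(F)F)c4)c3)cc2-c2ccncc2)c1` gives 99%; this is the lower of the two numbers, yet its gap to compound 1 lies within the scatter, so the two values cannot be told apart, and both sit close to an unchanged signal. Compound 3 `COc1cc(Cl)cc(-c2nn(-c3cccc(NC(=O)Nc4cccc(C(F)(F)F)c4)c3)cc2-c2ccncc2)c1` is the compound still to be measured. It differs from compound 2 in one place: hydrogen in place of chloro on an aromatic carbon. For the measured compounds named here, no step between two measured compounds is available, so the effect of this change cannot be read from any earlier pair. With compound 2 already showing 99% in this assay, hardly any room remains for a weaker effect, and nothing in the measured compounds points to a stronger one. The expected change is a number 1 percentage points higher from compound 2 to compound 3 (within the scatter), nothing beyond the scatter. Compound 3 is estimated at 100%, with a range from 88% to 110%.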

Compound 3, a percentage reported as activity, at one concentration (the size of the read-out at that concentration, not a potency): 101%
The estimate for compound 3 lay 1 percentage points below the measured number; low and high end bracket the measured number.
By their numbers in this assay, from the lowest: compounds 2, 3 and 1 (each within the scatter of the next).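

In this assay, for the compounds shown here, hydrogen in place of chloro, on an aromatic carbon ortho to a trifluoromethyl group and para to a large group, gives a number 2 percentage points higher from compound 2 to compound 3 (within the scatter) and so provides the first direct reading at this position. It shows that 4-chloro-3-(trifluoromethyl)phenyl and 3-(trifluoromethyl)phenyl cannot be told apart at the one concentration tested, with both compounds close to an unchanged signal. No information is available to explain this result.

Neither compound clearly moves the signal, so this step says little about how the position would behave in a compound with a clear effect. On these data alone, it also remains open whether an amine or a carboxylic acid on this carbon would give a stronger effect, and whether chloro and hydrogen differ at other concentrations.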